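The source may report more compounds than this note shows. Statements on the series, on what has been measured and on what is new or still open speak of the compounds shown alone.

Among the measured compounds shown here, compound 1 `COC(=O)C1=C(C)N=C(C)/C(=C(\O)OC)C1c1c(Cl)cccc1Cl` gives 1.91 nM in a functional assay (muscle tissue) with Cavia porcellus as the target (a lower number here means that less compound is needed, a higher number that more compound is needed for the effect), the lowest of the two numbers measured so far; compound 2 `COC(=O)C1=C(C)N=C(C)/C(=C(\O)OC)C1c1cccc(C)c1` gives 110 nM in this assay. For the measured compounds named here, the one measured step, a 58-fold higher number from compound 1 to compound 2 (1.76 log units; beyond the scatter), was large and beyond the scatter. Compound 3 `COC(=O)C1=C(C)N=C(C)/C(=C(\O)OC)C1c1ccc(C#N)cc1` differs from compound 1 by 4-cyanophenyl in place of 2,6-dichlorophenyl on a saturated ring carbon. Going by the values given here, as with the step to compound 2, the 2,6-dichlorophenyl group of compound 1 is given up for a phenyl ring carrying a single substituent, and that one measured step is the only guide available here; it points to a much higher number once the 2,6-dichlorophenyl group is lost. Compound 3 is therefore expected to show a large rise in this assay, a 160-fold higher number from compound 1 to compound 3 (2.20 log units; beyond the scatter). The estimate for compound 3 in this assay is 300 nM, with a range from 60 nM to 1500 nM.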

Compound 3, half-maximal effective concentration: 3470 nM
Compound 3: the middle estimate sits 12-fold (1.06 log units) below what was measured, outside the stated range (above it).
By their numbers in this assay, from the lowest: compound 1; then compound 2; then compound 3.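

In this assay, among the compounds shown here, replacing 2,6-dichlorophenyl with 4-cyanophenyl on the saturated ring carbon gives a 1800-fold higher number from compound 1 to compound 3 (3.26 log units; beyond the scatter), the largest step seen at this position so far. The earlier compounds shown here showed only that one singly substituted phenyl ring gave a higher number than 2,6-dichlorophenyl, whereas 4-cyanophenyl in place of 3-methylphenyl gives a 32-fold higher number from compound 2 to compound 3 (1.50 log units; beyond the scatter), so two singly substituted rings are also far apart here. Nothing on hand explains these differences.

Compounds 2 and 3 differ in both the substituent and its place on the phenyl ring, so the contribution of each remains unresolved. Also open, from the compounds shown here alone, is where 3-cyanophenyl, 4-methylphenyl or a phenyl ring bearing a single chlorine would fall.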